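Working notes: ester chain shortening and cell toxicity

The source may hold more compounds than are shown below. What is called first, only, known or untested is meant among the compounds shown, and "the series" means these compounds.

Measured so far in an ADME assay on Vero cells (Chlorocebus sabaeus) for cytotoxicity, read by XTT assay, with a stated time of 72 h; on this read-out lower numbers stand for higher toxicity in this test and higher numbers for lower toxicity in this test:
- compound 1 `CC1=C(C(=O)Nc2ccccc2Cl)C(c2ccc(Br)cc2)NC(=O)N1`: > 100000 nM
- compound 2 `COC(=O)C1=C(C)NC(=S)NC1c1cccs1`: "non-toxic" (no number reported)
- compound 3 `CCOC(=O)C1=C(C)NC(=S)NC1c1ccc(Br)cc1`: 38900 nM

In this assay, going by the values given here, compound 3 gives 38900 nM, the only plain number in the set. For compound 1 the entry > 100000 nM is a limit of this assay and not a number. Compound 2 is recorded in this assay only as "non-toxic" (no number reported), with no figure attached. Among the compounds with values here, compound 3 therefore stands alone as a measured figure, and no step between measured compounds can be stated from this set.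

Compound 4 `COC(=O)C1=C(C)NC(=S)NC1c1ccc(Br)cc1` differs from compound 3 by hydrogen in place of methyl on a saturated chain carbon bound to an oxygen next to a carbonyl group. Within the data shown here, no measured pair shows this kind of change here. The expectation for compound 4 in this assay is a step of a 1.0-fold higher number from compound 3 to compound 4 (0.01 log units; within the scatter) that stays within the usual scatter, with no direction preferred. On that basis compound 4 is estimated at 40000 nM, with a range from 15000 nM to 100000 nM.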

Compound 4, half-maximal cytotoxic concentration: 97200 nM
For compound 4 the middle estimate is 2.4-fold (0.39 log units) below the measured one; measured number inside the range.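

In this assay, going by these compounds alone, the ester gives the first step that can be read: ethyl to methyl, with the rest of the structure unchanged, gives a 2.5-fold higher number from compound 3 to compound 4 (0.40 log units; beyond the scatter). Within the data shown here, the earlier compounds gave no step at all, so this is the first sign that the read-out responds to this position, and a change of a single carbon is enough to move it beyond the usual scatter, towards lower toxicity in this test. Compound 1 holds the only limit in the set, and that entry is a limit of this assay and not a number: the limit of > 100000 nM in this assay, at which 1 of the 4 values shown sits.

This single pair gives one change in one direction on one aryl background, so it cannot show whether the trend extends to other ester groups. Going by these compounds, a longer chain such as propyl or butyl, or a carboxylic acid in place of the ester, remains open.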